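The source may hold more compounds than are shown below. What is called first, only, known or untested is meant among the compounds shown, and "the series" means these compounds.

Measured in a functional assay on the whole organism (strain albino) with Mus musculus as the target, with a stated time of 0.5 h; a higher number here means that more compound is needed for the effect, a lower number that less compound is needed:
- Compound 1 `COc1ccc(C2CC(Nc3nc4ccc(C)cc4s3)=NN2C(C)=O)cc1`: 39.4 umol/kg
- Compound 2 `COc1ccc(C2CC(Nc3nc4ccc([N+](=O)[O-])cc4s3)=NN2C(C)=O)cc1`: 149 umol/kg

Compound 1 stands lowest of the two, at 39.4 umol/kg. Compound 3 `CC(=O)N1N=C(Nc2nc3ccc(C)cc3s2)CC1c1ccc(O)cc1` departs from it by one change, hydrogen in place of methyl on an oxygen on an aromatic ring, or methoxy to hydroxy. Among the compounds with values here, no measured step covers this change. The only one, a 3.8-fold higher number from compound 1 to compound 2 (0.58 log units; beyond the scatter), swaps methyl for nitro on an aromatic carbon, so it offers only a rough size. In this assay a step no larger is expected, leaning weakly towards a higher number. The expected step is a 1.4-fold higher number from compound 1 to compound 3 (0.14 log units; within the scatter). For compound 3 the estimate is 55 umol/kg, with an expected range from 18 umol/kg to 160 umol/kg.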

Compound 3, dose for half-maximal effect: 54.3 umol/kg
The estimate for compound 3 lay 1.0-fold (0.01 log units) above the measured number; measured number inside the range.
By their numbers in this assay, from the lowest: compounds 1 and 3 (each within the scatter of the next); then compound 2.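

In this assay, within the data shown here, the step from methoxy to hydroxy is a 1.4-fold higher number from compound 1 to compound 3 (0.14 log units; within the scatter), the first reading for this end of the molecule, since the earlier pair differed only by methyl and nitro on an aromatic carbon. Here, removing the methyl from the oxygen on the aromatic ring leaves the number within the scatter. Nothing available accounts for the size of this step. The compounds shown leave open whether an amine or an ethoxy group in place of methoxy would behave like hydroxy, and whether the same change would read alike in compound 2.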